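Triazole aryl swap: compound 4 against compound 3

A few compounds are considered here, and "the series" means these few. Any claim that something is new, unique, unknown or untested is made for them only; others in the source may bear on it.

Values in an ADME assay on L02 cells (Homo sapiens) for antiproliferative activity, read by MTT assay, with a stated time of 48 h; on this read-out higher numbers stand for weaker inhibition and lower numbers for stronger inhibition:
compound 1 `N#CC1=C(N)Oc2c(N)cc3nc4ccccc4nc3c2C12C(=O)N(Cc1cnnn1-c1ccccc1Br)c1ccccc12` — 29200 nM
compound 2 `N#CC1=C(N)Oc2c(N)cc3nc4ccccc4nc3c2C12C(=O)N(Cc1cnnn1-c1cccc(C(F)(F)F)c1)c1ccccc12` — 38100 nM
compound 3 `Cc1ccc(C)c(-n2nncc2CN2C(=O)C3(C(C#N)=C(N)Oc4c(N)cc5nc6ccccc6nc5c43)c3ccccc32)c1` — only a limit of the assay, > 50000 nM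

Compound 3 sits at the limit (the limit of > 50000 nM in this assay, at which 1 of the 3 values shown sits), so its position is known only as a floor. The steps that reach it, an at least 1.7-fold higher number from compound 1 to compound 3 (0.23 log units; that floor lies within the scatter) and an at least 1.3-fold higher number from compound 2 to compound 3 (0.11 log units; that floor lies within the scatter), stay within the scatter, as does a 1.3-fold higher number from compound 1 to compound 2 (0.12 log units; within the scatter).

Compound 4 `N#CC1=C(N)Oc2c(N)cc3nc4ccccc4nc3c2C12C(=O)N(Cc1cnnn1-c1cc(Cl)ccc1Cl)c1ccccc12` differs from compound 3 by 2,5-dichlorophenyl in place of 2,5-dimethylphenyl on an aromatic nitrogen. All three measured steps change the aryl group on the same aromatic nitrogen, and none leaves the scatter. The expectation for this step is therefore no shift beyond the scatter, a step that the limit leaves unreadable from compound 3 to compound 4, with a fair chance that the assay again reports only a limit. Compound 4 is estimated at 55000 nM, within 28000 nM to 110000 nM.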

Compound 4, half-maximal inhibitory concentration: > 50000 nM
Compound 4 gave a limit, no number; the forecaster's own chance of this, stated with the estimate: 55%; the middle value does not contradict the limit.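

In this assay, compound 4 gives a limit and not a number, as compound 3 does: the limit of > 50000 nM in this assay, at which 2 of the 4 values shown sit.

The step between these two limits cannot be read. The floors an at least 1.3-fold higher number from compound 2 to compound 4 (0.11 log units; that floor lies within the scatter) and an at least 1.7-fold higher number from compound 1 to compound 4 (0.23 log units; that floor lies within the scatter) both lie within the scatter, so 2,5-dichlorophenyl on this aromatic nitrogen is not separated from 3-(trifluoromethyl)phenyl or 2-bromophenyl.

The compounds shown do not tell how far the true values of compound 3 and compound 4 lie past the limit. Also open, from the compounds shown here alone, is whether an amine or a carboxylic acid on this phenyl ring would move the value beyond the scatter from compound 1.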